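Replacing a Thiazole with Isobutyl: Expected Cytotoxicity

The source may hold more compounds than are shown below. What is called first, only, known or untested is meant among the compounds shown, and "the series" means these compounds.

Measured compounds:
Compound 1, `CC(C)CCn1nc(-c2cccs2)c(O)c(C2=NS(=O)(=O)c3cc(N(C)S(C)(=O)=O)ccc3N2)c1=O`. In an ADME assay on Huh-7 cells (Homo sapiens) for cytotoxicity, with a stated time of 72 h (on this read-out lower numbers stand for higher toxicity in this test and higher numbers for lower toxicity in this test), compound 1 gives > 33000 nM, which is a limit of the assay.
Compound 2, `CC(C)CCn1nc(-c2cccs2)c(O)c(C2=NS(=O)(=O)c3cc(S(C)(=O)=O)ccc3N2)c1=O`. In this assay compound 2 gives "not determined" (no result reported).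
Compound 3, `CC(C)CCn1nc(-c2cncs2)c(O)c(C2=NS(=O)(=O)c3cc(NS(C)(=O)=O)ccc3N2)c1=O`. In this assay compound 3 gives > 33000 nM, again a limit of the assay.

Compound 3 therefore stands at the edge of what this assay can report, with no single number of its own. For the measured compounds named here, the same holds for compound 1, and compound 2 has no result at all, so there is no measured step between any two compounds here; the only fixed point is the limit of > 33000 nM in this assay, at which 2 of the 3 values shown sit.

Compound 4, `CC(C)CCn1nc(CC(C)C)c(O)c(C2=NS(=O)(=O)c3cc(NS(C)(=O)=O)ccc3N2)c1=O`, differs from compound 3 in one place: isobutyl in place of 1,3-thiazol-5-yl on an aromatic carbon.

Going by the values given here, with no measured step to lean on, the expectation is that the change from compound 3 to compound 4 shifts toxicity in this assay by nothing beyond the usual scatter, that is a step that the limit leaves unreadable from compound 3 to compound 4. Compound 4 is thus expected to sit at or past the reporting limit as well, with an estimated value of 50000 nM, likely between 25000 nM and 150000 nM, though a single number may again not be reported.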

Compound 4, half-maximal cytotoxic concentration: > 1000 nM
Compound 4 ended at the assay's limit; the forecaster's own chance of this, stated with the estimate: 85%; the middle value does not contradict the limit.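

Compound 3 and compound 4 both end at limits of the assay rather than at single numbers, so the step between them cannot be read. As far as these compounds go, what stays open is whether isobutyl in place of 1,3-thiazol-5-yl changes toxicity at all in this assay.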